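The source may hold more compounds than are shown below. What is called first, only, known or untested is meant among the compounds shown, and "the series" means these compounds.

Compound 1 `O/N=C(\COc1cccc2ccccc12)c1ccc(F)cc1` is one of a pair of oximes built on a shared core that carries a halogen on the aromatic ring. In an ADME assay on NPC-TW01 cells (Homo sapiens) for cytotoxicity, read by MTT assay (a lower number here means a stronger inhibitor, a higher number a weaker inhibitor), compound 1 gives > 50000 nM, which is a limit of the assay and not a number. Its partner, compound 2 `O/N=C(\COc1cccc2ccccc12)c1ccc(Cl)cc1`, differs only by chloro in place of fluoro on an aromatic carbon. In this assay compound 2 gives > 50000 nM, again a limit rather than a number. The step that the two limits leave unreadable from compound 1 to compound 2 is therefore unreadable in size, both values sitting at the limit of > 50000 nM in this assay, at which 2 of the 2 values shown sit.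

The unmeasured compound 3 `COc1ccc(/C(COc2cccc3ccccc23)=N/O)cc1` departs from compound 1 by methoxy in place of fluoro on an aromatic carbon. Going by the values given here, no measured step covers an exchange of this kind; the only step available, from compound 1 to compound 2, shows no number at all. With compound 1 at a limit, the expectation for compound 3 is that it too stays at or beyond that limit in this assay. Compound 3 is expected to give 60000 nM, within 20000 nM to 200000 nM. The expected step that the limit leaves unreadable from compound 1 to compound 3 is thus estimated to be none beyond the scatter.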

Compound 3, half-maximal inhibitory concentration: 32300 nM
Compound 3: middle estimate off by 1.9-fold (0.27 log units), on the high side, within the range that was stated.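

Going by these compounds alone, at this position, on an aromatic carbon para to a large group, compound 3 is the first of the three compounds to give a reading rather than a limit in this assay, so methoxy is the first group here whose exchange can be given any size at all. Methoxy in place of fluoro gives an at least 1.5-fold lower number from compound 1 to compound 3 (0.18 log units; that floor lies within the scatter), and methoxy in place of chloro gives an at least 1.5-fold lower number from compound 2 to compound 3 (0.18 log units; that floor lies within the scatter). Both steps are floors only, and with those floors inside the scatter they do not establish a real difference, while the true size stays open for this reason: the limit of > 50000 nM in this assay, at which 2 of the 3 values shown sit.

A single group with a reading at this position is too little to support any pattern, so the compounds shown leave open how the reading would respond to an amine, a carboxylic acid or a trifluoromethyl group in the same place. They also leave open whether a longer chain such as ethoxy in place of methoxy would move the value further, and whether any change at this position can bring a step clearly beyond the scatter.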